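This account rests on a few compounds, and the source may have more. Where it says the series, first, only, none or still open, it means among the compounds named here.

Measured so far:
Compound 1 `CC(C)S(=O)(=O)NC(=O)c1ccc(Nc2nc(NC3(c4ccc(Cl)cc4)CC3)nc(OCC(F)(F)F)n2)cc1` gives 100% in an ADME assay on microsomes from liver (Homo sapiens) for metabolic stability, with a stated time of 10 min; a lower number here means that less of the compound is left, a higher number that more of the compound is left.
Compound 2 `CNC(=O)NCCS(=O)(=O)NC(=O)c1ccc(Nc2nc(NC3(c4ccc(Cl)cc4)CC3)nc(OCC(F)(F)F)n2)cc1` gives 97% in this assay.

Compound 2 stands alongside compound 1, the two numbers lying within the usual scatter of each other: a number 3 percentage points lower from compound 1 to compound 2 (within the scatter). Compound 3 `O=C(NS(=O)(=O)c1ccc(F)cc1)c1ccc(Nc2nc(NC3(c4ccc(Cl)cc4)CC3)nc(OCC(F)(F)F)n2)cc1` has not yet been measured. It differs from compound 2 in one place: 4-fluorophenyl in place of 2-((methylcarbamoyl)amino)ethyl on a sulfonyl sulfur. Among the compounds with values here, only one measured step bears on the group carried by the sulfonyl sulfur, namely a number 3 percentage points lower from compound 1 to compound 2 (within the scatter), and that step stayed within the scatter. Both measured compounds leave nearly all of the material intact after the stated time, so there is little room for an upward move. On this basis no step beyond the scatter is expected for compound 3: a number 2 percentage points lower from compound 2 to compound 3 (within the scatter). Compound 3 is therefore estimated at 95%, with a range from 80% to 100%.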

Compound 3, percent of the compound remaining: 100%
Beside the measured number, compound 3's estimate is 5 percentage points below it, and the stated range covers the measured number.
By their numbers in this assay, from the lowest: compounds 2, 1 and 3 (each within the scatter of the next).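

Compound 1 and compound 2 carry open chains on a sulfonyl sulfur, and compound 3 shows that a six-membered aromatic ring can stand there too in this assay without a step beyond the scatter. Putting 4-fluorophenyl in place of the chain gives a number 3 percentage points higher from compound 2 to compound 3 (within the scatter) and, against the smaller isopropyl group, no change at the digits printed from compound 1 to compound 3 (within the scatter) as well. No measurement shown here explains why the number holds across such different groups.

All three numbers sit at or close to the top of the read-out, so these compounds do not show which group on a sulfonyl sulfur, if any, would leave clearly less of the compound intact. An amine, a carboxylic acid, a longer chain or a phenyl ring without its fluorine at this place remains an open question.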